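Shortening the Basic Side Chain on a Chromone Scaffold

A few compounds are considered here, and "the series" means these few. Any claim that something is new, unique, unknown or untested is made for them only; others in the source may bear on it.

Measured compounds:
compound 1, `CCN(CC)CCCCOc1c(OCc2ccccc2)cc2oc(-c3ccccc3)cc(=O)c2c1O`, 2200 nM
compound 2, `COc1cc2oc(-c3ccccc3)cc(=O)c2c(O)c1OCCCCN1CCCC1`, 4900 nM
compound 3, `CCN(CC)CCCOc1c(OC)cc2oc(-c3ccccc3)cc(=O)c2c1O`, 3700 nM

The three compounds share one core and differ in the basic side chain and in the neighbouring alkoxy group. In a functional assay on HepG2 cells (Homo sapiens) for antiproliferative activity, read by MTT assay, with a stated time of 48 h (on this read-out higher numbers stand for weaker inhibition and lower numbers for stronger inhibition), compound 1 gives the lowest of the three numbers: compound 3 lies within the scatter of it, while compound 2 sits beyond the scatter above it.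

The unmeasured compound 4, `CN(C)CCCOc1c(OCc2ccccc2)cc2oc(-c3ccccc3)cc(=O)c2c1O`, is derived from compound 1 by the change (dimethylamino in place of (diethylamino)methyl on a saturated chain carbon, three bonds along the chain from an oxygen on an aromatic ring).

For the measured compounds named here, the only measured step that touches the amine is a 1.3-fold lower number from compound 2 to compound 3 (0.12 log units; within the scatter), a swap of one small tertiary amine for another that left the number essentially unchanged. Going by the values given here, the change from compound 1 to compound 4 also exchanges one tertiary amine for another, but at the same time shortens the chain by a unit, and no measured pair isolates that shortening. Compounds 1 and 3 differ in both chain length and alkoxy group, so their values cannot be separated into parts.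

Compound 4 is therefore expected to land close to compound 1, with a 1.3-fold higher number from compound 1 to compound 4 (0.10 log units; within the scatter) lying within the scatter, and its estimate is 2800 nM, ranging from 1200 nM to 6500 nM.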

Compound 4, half-maximal inhibitory concentration: 2200 nM
Estimate against measurement, compound 4: 1.3-fold (0.10 log units) above; low and high end bracket the measured number.
By their numbers in this assay, from the lowest: compounds 1, 4, 3 and 2 (each within the scatter of the next, the first and the last beyond it).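

In this assay, exchanging 4-(diethylamino)butyl for 3-(dimethylamino)propyl gives no change at the digits printed from compound 1 to compound 4 (within the scatter), so this position accepts the two chains equally on the otherwise unchanged core of compound 1. For the compounds shown here, the earlier compounds could not show this, as their one step between measured compounds kept the chain length fixed and compared only two amines, whereas this pair alters the chain length and the amine together and the group that enters has fewer heavy atoms than the one that leaves. No measurement given here accounts for this flat result, which stands only as an observation on this one pair.

The compounds shown leave open whether chain length and amine are each without effect here or whether their separate effects offset one another, a question that 4-(dimethylamino)butyl or 3-(diethylamino)propyl on the core of compound 1 would address by changing one feature at a time. They also leave open how a longer chain, or a primary amine at the chain end, would read in this assay.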